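Swapping an Ester Arm for a Benzyl Group

The source may hold more compounds than are shown below. What is called first, only, known or untested is meant among the compounds shown, and "the series" means these compounds.

Measured compounds:
compound 1, `CCOC(=O)Cn1c(=O)n(C2OC(CO)[C@@H](O)[C@H]2O)c2nc(N)nc(O)c21`, 86%
compound 2, `C=CCn1c(=S)n(C2OC(COC(C)=O)[C@H]3OC(C)(C)O[C@@H]23)c2nc(N)nc(O)c21`, 141%
compound 3, `C=CCn1c(=S)n(COCCO)c2nc(N)nc(O)c21`, 9%

All three compounds share one core and were tested in a functional assay on the whole organism (B cells) with Mus musculus as the target; on this read-out higher numbers stand for larger maximal responses and lower numbers for smaller maximal responses. Compound 1 gives 86%, which is the second highest of the three numbers. Compound 2 gives 141%, a higher number, and the gap between compound 1 and compound 2 is beyond the usual scatter. Compound 3 gives 9%, a far lower number, and that gap is also beyond the scatter.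

Compound 4, `Nc1nc(O)c2c(n1)n(C1OC(CO)[C@@H](O)[C@H]1O)c(=O)n2Cc1ccccc1`, has not yet been measured. It differs from compound 1 in a single place: phenyl in place of ethoxycarbonyl on a saturated chain carbon bound to an aromatic nitrogen. Among the measured compounds shown here, no measured pair shows this exchange, so its effect in this assay cannot be read from the data; what is known is that compound 1, with its ester arm, already reaches a high maximal response.

The step from compound 1 to compound 4 is expected to be a number 6 percentage points lower from compound 1 to compound 4 (within the scatter), which is no larger than the scatter. In this assay compound 4 is expected to give 80%, with a likely range from 40% to 130%.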

Compound 4, largest response reached (reported as maximal response), in percent of the reference or control that the assay uses: 110%
The estimate for compound 4 lay 30 percentage points below the measured number; the measured number falls inside the stated range.
By their numbers in this assay, from the lowest: compound 3; then compound 1; then compound 4; then compound 2.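

With phenyl in place of ethoxycarbonyl on a saturated chain carbon bound to an aromatic nitrogen, this assay shows a number 24 percentage points higher from compound 1 to compound 4 (beyond the scatter) and so this position does not depend on the ester arm for a high maximal response. The entering group has no hydrogen-bond acceptors and one six-membered aromatic ring of carbon only, whereas the group that leaves has two acceptors and no ring, so this arm tolerates a marked change in makeup. No measured evidence explains the step.

The compounds shown leave open whether the higher number comes from gaining the aromatic ring or from losing the ester. A carboxylic acid in place of the ester, or a longer chain carrying the phenyl, would help separate these two readings.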